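Hydroxy in Place of Nitro: What to Expect for Compound 4

The source may report more compounds than this note shows. Statements on the series, on what has been measured and on what is new or still open speak of the compounds shown alone.

Of the compounds shown here, three sharing one core have been measured. Compound 1 `Nc1sc2c(c1-c1nc3ccccc3s1)CCCC2` is the parent, compound 2 `Clc1ccc(/C=N/c2sc3c(c2-c2nc4ccccc4s2)CCCC3)cc1` carries a 4-chlorophenyl on the carbon double-bonded to nitrogen, and compound 3 `O=[N+]([O-])c1ccccc1/C=N/c1sc2c(c1-c1nc3ccccc3s1)CCCC2` carries a 2-nitrophenyl there. In an ADME assay on cells (Rhabdomyosarcoma cell, Homo sapiens) for cytotoxicity, read by MTT assay, with a stated time of 72 h (on this read-out lower numbers stand for higher toxicity in this test and higher numbers for lower toxicity in this test), compound 1 gives 253 ug/mL, compound 2 gives 367 ug/mL and compound 3 gives 255 ug/mL. Compound 3 thus holds the second highest of the three numbers, but all three lie within the usual scatter of one another, so no ordering among them can be claimed.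

Compound 4 `Oc1ccccc1/C=N/c1sc2c(c1-c1nc3ccccc3s1)CCCC2` differs from compound 3 by hydroxy in place of nitro on an aromatic carbon. The two measured steps, a 1.5-fold higher number from compound 1 to compound 2 (0.16 log units; within the scatter) and a 1.4-fold lower number from compound 2 to compound 3 (0.16 log units; within the scatter), both stayed within the scatter, and the second of them, a swap of the ring substituent on the same carbon, is the closest relative of the present change. Neither step, however, is the very same exchange, so the expectation rests on the observation that changes at this part of the molecule have so far not moved this assay. Compound 4 is therefore expected to show a 1.1-fold higher number from compound 3 to compound 4 (0.02 log units; within the scatter), with a value estimated at 270 ug/mL, within a range from 150 ug/mL to 480 ug/mL.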

Compound 4, half-maximal cytotoxic concentration: 42.4 ug/mL
Compound 4: the middle estimate sits 6.4-fold (0.80 log units) above what was measured; measured number below the stated range.
By their numbers in this assay, from the lowest: compound 4; then compounds 1, 3 and 2 (each within the scatter of the next).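

In this assay, going by these compounds alone, this position proves able to move the number after all: hydroxy in place of nitro gives a 6.0-fold lower number from compound 3 to compound 4 (0.78 log units; beyond the scatter) and is the first exchange to step beyond the scatter. Compound 4 also stands apart from the other two compounds, with an 8.7-fold lower number from compound 2 to compound 4 (0.94 log units; beyond the scatter) and a 6.0-fold lower number from compound 1 to compound 4 (0.78 log units; beyond the scatter), whereas compounds 1, 2 and 3 remain within the scatter of one another. The quiet results among those three therefore do not mean that this part of the molecule is indifferent to change, since here 2-hydroxyphenyl alone goes with higher toxicity in this test.

Nothing available explains why this exchange has so large an effect.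

The compounds shown cannot separate the effect of the hydroxy group itself from that of its place on the ring, a question that 4-hydroxyphenyl and 2-methoxyphenyl analogues would address. They also leave open whether an amine or a carboxylic acid on the same ring carbon would lower the number as hydroxy does or leave it among the values of compounds 1, 2 and 3.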